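Bromophenyl change on a carbonyl carbon

This account rests on a few compounds, and the source may have more. Where it says the series, first, only, none or still open, it means among the compounds named here.

Values in a functional assay on DU-145 cells (Homo sapiens) for cytotoxicity, read by MTT assay, with a stated time of 68 h; on this read-out lower numbers stand for stronger inhibition and higher numbers for weaker inhibition:
- compound 1 `O=C(/C=C/c1cccc(OCc2ccccc2)c1)c1ccc([N+](=O)[O-])cc1`: 52500 nM
- compound 2 `O=C(/C=C/c1cccc(OCc2ccccc2)c1)c1ccccc1Br`: 3000 nM

Compound 2 holds the lower of the two numbers in this assay, and the gap to compound 1 lies beyond the scatter. The next change leads to compound 3 `O=C(/C=C/c1cccc(OCc2ccccc2)c1)c1cccc(Br)c1`: 3-bromophenyl in place of 2-bromophenyl on a carbonyl carbon. In words, 3-bromophenyl stands in place of 2-bromophenyl on a carbonyl carbon. Among the measured compounds shown here, only one measured step bears on this change, and only indirectly: an 18-fold lower number from compound 1 to compound 2 (1.24 log units; beyond the scatter), a large step made by 2-bromophenyl replacing 4-nitrophenyl at the same carbonyl carbon. For the measured compounds named here, no measured pair isolates the change from 2-bromophenyl to 3-bromophenyl. A smaller step towards a higher number is therefore expected, and it may not clear the scatter. The expected step is a 2.0-fold higher number from compound 2 to compound 3 (0.30 log units; within the scatter). For compound 3, the estimate in this assay is 6000 nM, with an expected range of 1800 nM to 22000 nM.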

Compound 3, half-maximal inhibitory concentration: 9100 nM
Compound 3: middle estimate off by 1.5-fold (0.18 log units), on the low side, and the stated range covers the measured number.
By their numbers in this assay, from the lowest: compound 2; then compound 3; then compound 1.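

In this assay, 2-bromophenyl and 3-bromophenyl hold the same atoms, joined differently, yet the change on the carbonyl carbon gives a 3.0-fold higher number from compound 2 to compound 3 (0.48 log units; beyond the scatter) and so shows that this position responds to where the bromine sits, not only to its presence. The gain over 4-nitrophenyl is smaller but not lost with 3-bromophenyl, which gives a 5.8-fold lower number from compound 1 to compound 3 (0.76 log units; beyond the scatter) in the same read-out, leaving both bromophenyl compounds on the lower side of compound 1, with compound 2 lowest of the three. No measurement shown here accounts for either step.

Still open, as far as these compounds go, is where 4-bromophenyl would fall, which would separate the bromine from the nitro group at one ring position. Also open, from the compounds shown here alone, is whether the order of compound 2 and compound 3 holds when the shared core carries an amine or a carboxylic acid.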